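Cytotoxicity at the limit across three carboxylic acids

The compounds below may be only part of what the source reports. "The series", "measured", "known", "first", "only" and "open" are said of these compounds alone.

Compound 1 `Cc1nc2c(c(-c3cc(F)c4c(c3C)CCCO4)c1[C@H](OC(C)(C)C)C(=O)O)CN(CCCc1ccccc1F)CC2` — in an ADME assay on MT2 cells (Homo sapiens) for cytotoxicity, read by XTT assay, with a stated time of 4 days (on this read-out lower numbers stand for higher toxicity in this test and higher numbers for lower toxicity in this test), compound 1 gives > 40000 nM, a limit of the assay.
Compound 2 `Cc1ccc(-c2c3c(nc(C)c2[C@H](OC(C)(C)C)C(=O)O)CCN(C(=O)NCc2ccccc2)C3)cc1` — in this assay compound 2 gives > 40000 nM, likewise a limit.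
Compound 3 `Cc1ccccc1CCCN1CCc2nc(C)c([C@H](OC(C)(C)C)C(=O)O)c(-c3cc(F)c4c(c3C)CCCO4)c2C1` — in this assay compound 3 gives > 40000 nM, again a limit.

All three measured compounds share a core and were tested in this assay. For the measured compounds named here, compound 2 stands at the limit, and the two further values also stand at that limit, so no compound is separated from another by a readable amount. Going by the values given here, the only measured pair that differs in one place is compound 1 and compound 3, and its step that the two limits leave unreadable from compound 1 to compound 3 is unreadable for the same reason, since both values are limits.

Compound 4 `Cc1ccc(-c2c3c(nc(C)c2[C@H](OC(C)(C)C)C(=O)O)CCN(C/C=C/c2ccccc2)C3)cc1` differs from compound 2 by 3-phenylprop-2-en-1-yl in place of benzylcarbamoyl on an amine nitrogen in a ring.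

Among the compounds with values here, no measured step bears on this change. Because the limit of > 40000 nM in this assay, at which 3 of the 3 values shown sit, holds every value shown, compound 4 is expected to stand at the same limit, with an expected step that the limit leaves unreadable from compound 2 to compound 4. Compound 4 is therefore estimated at 50000 nM, within 20000 nM to 150000 nM.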

Compound 4, half-maximal cytotoxic concentration: > 40000 nM
Compound 4 gave a limit, no number (the forecaster's own chance of this, stated with the estimate: 85%); the middle value does not contradict the limit.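

In this assay compound 4, like compound 2, gives only a limit, so no step between the two can be read: the limit of > 40000 nM in this assay, at which 4 of the 4 values shown sit.

The compounds shown leave open at what concentration any of them turns cytotoxic, and whether exchanging benzylcarbamoyl for 3-phenylprop-2-en-1-yl changes that concentration at all.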